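Mirror Image of an Azide Oxazolidinone: Compound 1 to 3

The compounds below may be only part of what the source reports. "The series", "measured", "known", "first", "only" and "open" are said of these compounds alone.

Measured so far:
compound 1 `[N-]=[N+]=NC[C@H]1CN(n2cccc2)C(=O)O1`: 200 nM
compound 2 `CN(C)C[C@H]1CN(n2cccc2)C(=O)O1`: 40000 nM

Of the two numbers obtained in an assay for inhibition of Amine oxidase [flavin-containing] A (Bos taurus) (a lower number here means a stronger inhibitor, a higher number a weaker inhibitor), compound 1 gives the lower one, and the gap is wide: a 200-fold higher number from compound 1 to compound 2 (2.30 log units; beyond the scatter). Compound 3 `[N-]=[N+]=NC[C@@H]1CN(n2cccc2)C(=O)O1` keeps every atom and bond of compound 1 and changes only the handedness at one carbon: the two compounds have the same atoms and bonds; at least one stereo element is drawn with a configuration in one of them and without one in the other: 1 of 2 stereo elements differ; a stereocentre at a saturated ring carbon is drawn R in compound 1 and S in compound 3. For the measured compounds named here, the single measured step, from compound 1 to compound 2, swaps a dimethylamino group in for the azido group and therefore tells nothing about what a change of configuration does; no measured pair bears on this step. Enantiomers can agree closely or differ widely, so the expectation for compound 3 in this assay is uncertain, leaning towards a somewhat higher number than compound 1 with a broad range: a 5.0-fold higher number from compound 1 to compound 3 (0.70 log units; beyond the scatter). Compound 3 is estimated at 1000 nM, most likely between 150 nM and 10000 nM.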

Compound 3, inhibition constant: 2500 nM
Beside the measured number, compound 3's estimate is 2.5-fold (0.40 log units) below it; measured number inside the range.
By their numbers in this assay, from the lowest: compound 1; then compound 3; then compound 2.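

In this assay, the handedness at this one saturated ring carbon clearly matters, with a 13-fold higher number from compound 1 to compound 3 (1.10 log units; beyond the scatter). For the compounds shown here, the earlier step showed only that replacing the azido group changes the number, a 200-fold higher number from compound 1 to compound 2 (2.30 log units; beyond the scatter), whereas this step shows that the same groups, arranged differently in space, also give a gap beyond the scatter, though a smaller one than that earlier step. With R in compound 1 and S in compound 3 as the only difference, the gap can be tied to this single stereocentre, although nothing here explains why the R form is the stronger inhibitor: the fact that one of compounds 1 and 3 is drawn with a defined configuration and the other without, at the place where they differ

The compounds shown leave open whether the R form stays ahead when the azido group gives way to another group, since compound 2 appears in one configuration only. Going by these compounds, it also remains open how a primary amine or a longer chain in that place would behave in either configuration.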